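This account rests on a few compounds, and the source may have more. Where it says the series, first, only, none or still open, it means among the compounds named here.

Measured so far in a functional assay on SW707 cells (Homo sapiens) for antiproliferative activity, read by sulforhodamine B assay, with a stated time of 72 h; a lower number here means a stronger inhibitor, a higher number a weaker inhibitor:

- compound 1, `Clc1ccccc1/C=N/c1nc2ccccc2[nH]1`: 63.4 uM
- compound 2, `O=[N+]([O-])c1ccc(/C=N/c2nc3ccccc3[nH]2)cc1`: 87.1 uM
- compound 3, `Brc1ccccc1/C=N/c1nc2ccccc2[nH]1`: 26.3 uM

Compound 2 carries the highest of the three numbers in this assay, yet its gap to compound 1 lies within the scatter, so the two cannot be ordered; only compound 3 stands apart from it, beyond the scatter. The unmeasured compound 4 is `Brc1ccc(/C=N/c2nc3ccccc3[nH]2)cc1`. It differs from compound 2 in one place: bromo in place of nitro on an aromatic carbon.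

Within the data shown here, no measured pair swaps a nitro for a bromo, so no step bears on the change directly. Among the measured compounds shown here, the one measured step that involves a bromo is a 2.4-fold lower number from compound 1 to compound 3 (0.38 log units; beyond the scatter), a modest move toward a lower number; it concerns a different position and a different leaving group, so it is only a loose guide. For the measured compounds named here, nothing among the measured compounds links a nitro group to a higher or lower number in this assay.

On that basis a moderate step toward a lower number is expected, a 2.2-fold lower number from compound 2 to compound 4 (0.34 log units; beyond the scatter), though with wide uncertainty. Compound 4 is therefore estimated at 40 uM, within a range of 15 uM to 110 uM.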

Compound 4, concentration for 50% inhibition: 33.3 uM
Beside the measured number, compound 4's estimate is 1.2-fold (0.08 log units) above it; low and high end bracket the measured number.
By their numbers in this assay, from the lowest: compounds 3, 4, 1 and 2 (each within the scatter of the next, the first and the last beyond it).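

In this assay, among these compounds, putting bromo in place of nitro on an aromatic carbon, para to a large group, gives a 2.6-fold lower number from compound 2 to compound 4 (0.42 log units; beyond the scatter), which is the first comparison of two groups at this position. Together with a 2.4-fold lower number from compound 1 to compound 3 (0.38 log units; beyond the scatter), it gives two measured steps in which the compound carrying bromo has the lower number, against chloro in one pair and nitro in the other, though the two steps concern different positions and different departing groups. No measurement shown here accounts for the lower number with bromo, so the change can be recorded but not explained.

Only nitro and bromo appear at this position, so the compounds shown cannot tell whether the lower number is particular to bromo or would also appear with chloro, an amine, a methoxy group or a carboxylic acid in the same place. They also leave open whether the step seen here would hold on a different core, or in cells other than those of this assay.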